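Amide nitrogen substituent: methyl to cyclopropyl

This account rests on a few compounds, and the source may have more. Where it says the series, first, only, none or still open, it means among the compounds named here.

Measured so far:
- compound 1, `CCN(Cc1c[nH]nn1)C(=O)COc1ccc(C)cc1`, in an assay on HEK293 cells for agonist activity at transient receptor potential cation channel subfamily M member 8 (Homo sapiens), read by fluorescence and calcium flux, with a stated time of 15 min (on this read-out lower numbers stand for an effect already at smaller amounts and higher numbers for an effect only at larger amounts of compound), gives 31100 nM
- compound 2, `Cc1ccc(OCC(=O)N(C)Cc2cccs2)cc1`, in this assay gives 400 nM

Of the two numbers in this assay, compound 2 stands lowest. Its nearest neighbour is compound 1, whose number is higher by a margin well beyond the usual scatter, so on the data in hand compound 2 is clearly the more potent of the pair. Among the measured compounds shown here, no single-change step between the two measured compounds exists, as they differ in several places at once, so the two values show only that the pair is far apart.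

The next compound, compound 3, `Cc1ccc(OCC(=O)N(Cc2cccs2)C2CC2)cc1`, keeps the whole of compound 2 except one position: cyclopropyl in place of methyl on an amide-type nitrogen. There is no measured step of this kind in the set, so the expectation rests on compound 2 alone and on the modest size of the change. Compound 3 is expected to land close to compound 2, with a step of a 1.3-fold lower number from compound 2 to compound 3 (0.12 log units; within the scatter) that lies within the scatter. The estimate for compound 3 in this assay is 300 nM, with a range from 80 nM to 1200 nM.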

Compound 3, half-maximal effective concentration: 8 nM
The estimate for compound 3 lay 38-fold (1.57 log units) above the measured number; measured number outside the range, below it.
By their numbers in this assay, from the lowest: compound 3; then compound 2; then compound 1.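

The nitrogen substituent is a sensitive position in this assay: with the rest of the structure held constant, cyclopropyl in place of methyl gives a 50-fold lower number from compound 2 to compound 3 (1.70 log units; beyond the scatter), the first effect in the series that can be tied to a single place. Compound 1 and compound 2 differ in several places at once, so they could not show this. The change swaps 1 heavy atom for 3 heavy atoms and adds a three-membered ring of carbon only, with 0 hydrogen-bond donors, 0 hydrogen-bond acceptors and no net charge on either group, and no measurement in hand accounts for the size of the step.

Among the compounds shown here, the single step cannot separate a contribution from the ring itself from one tied to the larger number of carbon atoms, a question that isopropyl or cyclobutyl on the same nitrogen would bear on. Also open, from the compounds shown here alone, is whether the step holds in another setting, for instance with the thiophene-bearing part of compound 3 replaced by benzyl, or whether it belongs only to this combination of groups.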